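The source may report more compounds than this note shows. Statements on the series, on what has been measured and on what is new or still open speak of the compounds shown alone.

Measured so far: compound 1 `Cc1nc(S(C)(=O)=O)ccc1Oc1ncnc(OC2CCN(C(=O)OC3(C(F)(F)F)COC3)CC2)c1F` gives 29.3 nM in a functional assay on isolated protein for inhibition of Glucose-dependent insulinotropic receptor (Homo sapiens), read by HTRF and cAMP accumulation (on this read-out higher numbers stand for an effect only at larger amounts of compound and lower numbers for an effect already at smaller amounts), and compound 2 `Cc1nc(S(C)(=O)=O)ccc1Oc1ncnc(OC2CCN(C(=O)SC3(C)CC3)CC2)c1F` gives 13.2 nM in this assay.

Among the measured compounds shown here, compound 2 holds the lower of the two numbers; the one step seen is a 2.2-fold lower number from compound 1 to compound 2 (0.35 log units; beyond the scatter). Compound 3 `Cc1nc(S(C)(=O)=O)ccc1Oc1ncnc(OC2CCN(C(=O)C3CCCC3)CC2)c1F` differs from compound 2 by a group of 5 heavy atoms (5 carbon; one five-membered non-aromatic ring of carbon only) in place of a group of 5 heavy atoms (4 carbon, 1 sulfur; one three-membered non-aromatic ring of carbon only), on a carbonyl carbon. That single measured step also exchanged the group on this carbonyl carbon, but between a different pair of groups, so it bears on compound 3 only loosely. A modest shift, not far beyond the scatter, is therefore expected from compound 2 to compound 3, a 1.4-fold higher number from compound 2 to compound 3 (0.13 log units; within the scatter). Compound 3 is estimated at 18 nM, within 6 nM to 60 nM.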

Compound 3, half-maximal effective concentration: 72.8 nM
Compound 3: the middle estimate sits 4.0-fold (0.61 log units) below what was measured, outside the stated range (above it).
By their numbers in this assay, from the lowest: compound 2; then compound 1; then compound 3.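

On the carbonyl carbon bound to the amide-type nitrogen in a ring, cyclopentyl is not interchangeable with the sulfur-bearing group of the same heavy-atom count (a 5.5-fold higher number from compound 2 to compound 3 (0.74 log units; beyond the scatter)) in this assay. It also gives a higher number than the (3-(trifluoromethyl)oxetan-3-yl)oxy group (a 2.5-fold higher number from compound 1 to compound 3 (0.40 log units; beyond the scatter)), so among these three compounds, the two groups joined to the carbonyl through oxygen or sulfur give lower numbers than the one joined through carbon. Nothing available explains this order.

Still open, going by these compounds, is whether the linking atom accounts for this order, which a methylcyclopropyl group joined through oxygen or an amine nitrogen on this carbonyl would help to test.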